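Ortho-methyl on the chlorophenyl of compound 3

This account rests on a few compounds, and the source may have more. Where it says the series, first, only, none or still open, it means among the compounds named here.

Measured in a functional assay on HEK293 cells for positive allosteric modulation of metabotropic glutamate receptor 5 (Homo sapiens), read by FLIPR and calcium flux (on this read-out lower numbers stand for an effect already at smaller amounts and higher numbers for an effect only at larger amounts of compound), so far:
compound 1 `O=C(COCc1ccccc1)N1CCN(c2ccc(Cl)cc2)CC1` gives 350 nM
compound 2 `O=C(COCc1ccccc1)N1CCN(c2ccc(F)cc2)CC1` gives 1100 nM
compound 3 `O=C(COCc1ccncc1)N1CCN(c2ccc(Cl)cc2)CC1` gives 1300 nM

Compound 3 stands at the highest number of the three; its gap to compound 2 is within the scatter, while compound 1 lies clearly lower, seen in a 3.7-fold higher number from compound 1 to compound 3 (0.57 log units; beyond the scatter) and, for the halogen swap, a 3.1-fold higher number from compound 1 to compound 2 (0.50 log units; beyond the scatter). Compound 4 `Cc1cc(Cl)ccc1N1CCN(C(=O)COCc2ccncc2)CC1` differs from compound 3 by methyl in place of hydrogen on an aromatic carbon. Neither measured step touches this position, so the direction is open; both known steps were modest, and a step of similar size or none beyond the scatter is expected, a 1.2-fold lower number from compound 3 to compound 4 (0.07 log units; within the scatter). Compound 4 is thus estimated at 1100 nM in this assay, with a range of 300 nM to 4000 nM.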

Compound 4, half-maximal effective concentration: 240 nM
Compound 4: the middle estimate sits 4.6-fold (0.66 log units) above what was measured; the measured number lies below the stated range.
By their numbers in this assay, from the lowest: compounds 4 and 1 (each within the scatter of the next); then compounds 2 and 3 (each within the scatter of the next).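

In this assay, methyl on the aromatic carbon ortho to a large group gives a 5.4-fold lower number from compound 3 to compound 4 (0.73 log units; beyond the scatter), the first step shown that lowers the number. This position on the 4-chlorophenyl therefore responds to substitution, and a single added carbon is enough to move the value beyond the scatter. Nothing at hand accounts for this change.

Still open, on these data alone, is whether the same methyl lowers the number on compound 1, which carries phenyl in place of pyridin-4-yl. Also open, as far as these compounds go, is how ethyl or methoxy would behave on this carbon.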